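The source may hold more compounds than are shown below. What is called first, only, known or untested is meant among the compounds shown, and "the series" means these compounds.

Of the compounds shown here, two of a shared core have so far been measured in a functional assay on SF-539 cells (Homo sapiens) for inhibition, read by sulforhodamine B assay, with a stated time of 48 h; a lower number here means a stronger inhibitor of growth, a higher number a weaker inhibitor of growth. Compound 1, `COc1ccc(-c2[nH]c3ccc(OC)cc3c2/C=C(\C#N)S(=O)(=O)c2ccccc2)cc1`, gives 510 nM in this assay. Compound 2, `CC(=O)/C(=C\c1c(-c2ccccc2)[nH]c2ccccc12)S(=O)(=O)c1ccccc1`, gives 1300 nM, the higher of the two numbers, and the gap to compound 1 lies beyond the usual scatter, so compound 2 stands at the weaker end of what has been measured. Compound 3, `N#C/C(=C\c1c(-c2ccccc2)[nH]c2ccccc12)S(=O)(=O)c1ccccc1`, has not yet been measured; it differs from compound 2 by cyano in place of acetyl on a double-bonded chain carbon bound to a double-bonded chain carbon and a sulfonyl sulfur. Compound 1 already carries a cyano rather than an acetyl and gives the lower of the two numbers, but it also differs from compound 3 elsewhere on the core, so no direct step can be read from it. A moderate fall in the number, somewhat beyond the scatter, is expected a 1.9-fold lower number from compound 2 to compound 3 (0.27 log units; within the scatter). On that basis compound 3 is estimated at 700 nM, within a range from 250 nM to 2000 nM.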

Compound 3, concentration for 50% growth inhibition: 2500 nM
The estimate for compound 3 lay 3.6-fold (0.55 log units) below the measured number; the whole stated range lies below it.
By their numbers in this assay, from the lowest: compound 1; then compounds 2 and 3 (each within the scatter of the next).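

For the compounds shown here, this is the first direct reading at this position: in this assay, cyano in place of acetyl on a double-bonded chain carbon bound to a double-bonded chain carbon and a sulfonyl sulfur gives a 1.9-fold higher number from compound 2 to compound 3 (0.28 log units; within the scatter). On the shared core of compound 2 and compound 3, the two groups therefore cannot be told apart in this assay, although the acetyl is the larger group by heavy-atom count. No measurement shown offers an explanation for this result.

On these data alone, whether a carboxylic acid or an amide at the same place would move the number beyond the scatter stays open. Compound 1 differs from compound 2 and compound 3 in more than one place, so its steps to them cannot be read, and what its other core groups contribute remains unresolved.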